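The source may hold more compounds than are shown below. What is called first, only, known or untested is meant among the compounds shown, and "the series" means these compounds.

Measured in a functional assay on HepG2 cells (Homo sapiens) for antiproliferative activity, read by MTT assay, with a stated time of 48 h; on this read-out higher numbers stand for weaker inhibition and lower numbers for stronger inhibition:
- compound 1 `C#Cc1cccc(Nc2ncnc3cc(NC(=O)/C=C/c4ccccc4)sc23)c1`: 15400 nM
- compound 2 `COc1ccc(/C=C/C(=O)Nc2cc3c(Nc4cc(Cl)cc(Cl)c4)ncnc3s2)cc1`: 41800 nM
- compound 3 `O=C(/C=C/c1ccccc1)Nc1cc2c(Nc3cccc(Cl)c3F)ncnc2s1`: 44600 nM

Compound 1 holds the lowest number of the three, and the gaps to compound 2 and compound 3 both lie beyond the usual scatter. Compound 4 `O=C(/C=C/c1ccccc1)Nc1cc2ncnc(Nc3ccc(Cl)c(Cl)c3)c2s1` has not yet been measured. It carries 3,4-dichlorophenyl in place of 3-ethynylphenyl on a nitrogen on an aromatic ring. Within the data shown here, no measured pair isolates this change, so the expectation is tentative. It rests on compound 2 at 41800 nM and compound 3 at 44600 nM, which also carry chlorine. A moderate rise is expected in this assay, the estimated step being a 1.9-fold higher number from compound 1 to compound 4 (0.29 log units; within the scatter). For compound 4 the estimated value is 30000 nM, with an expected range of 12000 nM to 70000 nM.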

Compound 4, half-maximal inhibitory concentration: 13400 nM
Beside the measured number, compound 4's estimate is 2.2-fold (0.35 log units) above it; measured number inside the range.
By their numbers in this assay, from the lowest: compounds 4 and 1 (each within the scatter of the next); then compounds 2 and 3 (each within the scatter of the next).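

In this assay, exchanging 3-ethynylphenyl for 3,4-dichlorophenyl on the nitrogen gives a 1.1-fold lower number from compound 1 to compound 4 (0.06 log units; within the scatter). Among these compounds, this is the first pair to isolate this position, and it shows that the triple bond can be lost on the shared core with no change beyond the scatter. Nothing available explains why the two groups read alike. Going by these compounds, whether an amine or a carboxylic acid on this ring would also leave the number unchanged remains open, as does whether either group would read the same with a different chain on the amide.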